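The source may hold more compounds than are shown below. What is called first, only, known or untested is meant among the compounds shown, and "the series" means these compounds.

Measured compounds:
compound 1 `COc1ccc(C2CC(c3ccccc3)=NN2C(=O)c2ccc3c(c2)OCCO3)cc1`: 8370 nM
compound 2 `COc1ccc(C2=NN(C(=O)c3ccc4c(c3)OCCO4)C(c3ccccc3F)C2)cc1`: 3470 nM
compound 3 `COc1ccc(C2CC(c3ccccc3)=NN2C(=O)C2COc3ccccc3O2)cc1`: 5080 nM

All three were tested in a functional assay on WM 266-4 cells (Homo sapiens) for inhibition, read by MTT assay, with a stated time of 24 h; a lower number here means a stronger inhibitor of growth, a higher number a weaker inhibitor of growth. Compound 1 and compound 3 share a core and differ only by 2,3-dihydro-1,4-benzodioxin-2-yl in place of 2,3-dihydro-1,4-benzodioxin-6-yl on a carbonyl carbon; that change gave a 1.6-fold lower number from compound 1 to compound 3 (0.22 log units; within the scatter). Compound 2 has a different core from compound 1, and how the two cores differ is not broken down here. In this assay compound 2 gives 3470 nM and compound 3 gives 5080 nM, two numbers within the scatter of each other, while compound 1 gives 8370 nM.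

Compound 4 `COc1ccc(C2=NN(C(=O)C3COc4ccccc4O3)C(c3ccccc3F)C2)cc1` has not yet been measured. It differs from compound 2 by 2,3-dihydro-1,4-benzodioxin-2-yl in place of 2,3-dihydro-1,4-benzodioxin-6-yl on a carbonyl carbon, the same change as from compound 1 to compound 3. Because a 1.6-fold lower number from compound 1 to compound 3 (0.22 log units; within the scatter) lay within the scatter, a step of similar size is expected for compound 4, namely a 1.5-fold lower number from compound 2 to compound 4 (0.18 log units; within the scatter). Compound 4 is therefore estimated at 2300 nM, expected to fall between 1000 nM and 5500 nM.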

Compound 4, concentration for 50% growth inhibition: 5720 nM
The estimate for compound 4 lay 2.5-fold (0.40 log units) below the measured number, and the stated range ends below it.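

In this assay, putting 2,3-dihydro-1,4-benzodioxin-2-yl in place of 2,3-dihydro-1,4-benzodioxin-6-yl on the carbonyl carbon gave a 1.6-fold higher number from compound 2 to compound 4 (0.22 log units; within the scatter). Set beside the earlier step, the change did not carry over unchanged from one core to the other: the same change on two cores in this assay, a 1.6-fold lower number (0.22 log units; within the scatter) from compound 1 to compound 3 and a 1.6-fold higher number (0.22 log units; within the scatter) from compound 2 to compound 4, 2.7-fold (0.43 log units) apart, beyond the scatter of two such steps This rests on only two pairs, each step on its own within the scatter, and it does not show which difference between the cores is responsible or how the change would behave on any further core.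

The compounds shown leave open whether the two groups would compare in the same way on a core carrying an amine or a carboxylic acid in place of the methoxy group. They also leave open whether the gap between the two steps would appear in another cell line.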